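Carboxylic acid chain in place of cyclohexyl on the core

This account rests on a few compounds, and the source may have more. Where it says the series, first, only, none or still open, it means among the compounds named here.

Measured compounds:
- compound 1 `CC(C)Nc1nccc(-c2c[nH]nc2-c2ccc(Cl)cc2)n1`: 0.106 mL/min/kg
- compound 2 `Clc1ccc(-c2n[nH]cc2-c2ccnc(NC3CCCCC3)n2)cc1`: 0.156 mL/min/kg

In an in vitro ADME assay on microsomes from liver (Homo sapiens) for metabolic stability (on this read-out higher numbers stand for fast clearance and lower numbers for slow clearance), compound 1 gives 0.106 mL/min/kg, and compound 2 gives 0.156 mL/min/kg. Compound 2 holds the higher of the two numbers, but its nearest neighbour is compound 1, and the step of a 1.5-fold higher number from compound 1 to compound 2 (0.17 log units; within the scatter) lies within the scatter, so no real difference between them is shown.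

Compound 3 `C[C@H](CC(=O)O)Nc1nccc(-c2c[nH]nc2-c2ccc(Cl)cc2)n1` is not yet measured in this assay. It differs from compound 2 in one place: 1-(carboxymethyl)ethyl in place of cyclohexyl on a nitrogen on an aromatic ring.

Going by the values given here, only one measured step exists, the one from compound 1 to compound 2, and it swaps one ring-free or ring-bearing carbon group for another on that same nitrogen, staying within the scatter. Among the compounds with values here, no measured step introduces a carboxylic acid, so the data give no direct guide for this change. Compound 3 is therefore expected to show a 1.4-fold lower number from compound 2 to compound 3 (0.15 log units; within the scatter), with 0.11 mL/min/kg as the estimate and a range from 0.045 mL/min/kg to 0.27 mL/min/kg.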

Compound 3, clearance: < 0.006 mL/min/kg
Compound 3: no number, only a limit (the forecaster's own chance of this, stated with the estimate: 10%); middle value at least 18-fold (1.26 log units) from the limit.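

The earlier step on this nitrogen on an aromatic ring, a 1.5-fold higher number from compound 1 to compound 2 (0.17 log units; within the scatter), suggested that this assay barely registers a swap between the two carbon groups, isopropyl and cyclohexyl. The carboxylic acid chain shows that this position can matter a great deal: 1-(carboxymethyl)ethyl in place of cyclohexyl gives an at least 26-fold lower number from compound 2 to compound 3 (1.41 log units; beyond the scatter), and carboxy in place of hydrogen on the chain gives an at least 17-fold lower number from compound 1 to compound 3 (1.24 log units; beyond the scatter). Compound 3 has only a limit of the assay and no number, so the true size of both steps stays unknown: the limit of < 0.006 mL/min/kg in this assay, at which 1 of the 3 values shown sits.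

Going by these compounds, it remains open whether an amide or an amine at the end of the same chain would give a similar result in this assay. On these data alone, the effects of a longer chain carrying the carboxylic acid and of the opposite stereocentre also remain open.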